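The source may hold more compounds than are shown below. What is called first, only, known or untested is meant among the compounds shown, and "the series" means these compounds.

- Compound 1 `CN1CCN(C23CC(NCCC(=O)N4CCCC4)C(C(c4ccccc4)C2)C(c2ccccc2)C3)CC1`: 21500 nM
- Compound 2 `CCN(CC)CC(=O)NC1CC2(N3CCN(C)CC3)CC(c3ccccc3)C1C(c1ccccc1)C2`: 26400 nM

In an ADME assay on L6 cells (Rattus norvegicus) for cytotoxicity, read by fluorescence, with a stated time of 72 h (a lower number here means a stronger inhibitor, a higher number a weaker inhibitor), compound 2 gives 26400 nM, which lies within the scatter of compound 1. Compound 3 `CCN(CC)CCC(=O)NC1CC2(N3CCN(C)CC3)CC(c3ccccc3)C1C(c1ccccc1)C2` differs from compound 2 by one change, (diethylamino)methyl in place of diethylamino on a saturated chain carbon bound to a carbonyl carbon. Among the compounds with values here, the only measured step that bears on this is a 1.2-fold higher number from compound 1 to compound 2 (0.09 log units; within the scatter). It exchanges a whole group on an amine nitrogen, yet stays within the scatter. No step beyond the scatter is therefore expected in this assay, and the expected step is a 1.1-fold lower number from compound 2 to compound 3 (0.04 log units; within the scatter). Compound 3 is estimated at 24000 nM, with an expected range of 12000 nM to 48000 nM.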

Compound 3, half-maximal inhibitory concentration: 35900 nM
Estimate against measurement, compound 3: 1.5-fold (0.17 log units) below, within the range that was stated.
By their numbers in this assay, from the lowest: compounds 1, 2 and 3 (each within the scatter of the next).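

In this assay, the step with (diethylamino)methyl in place of diethylamino on a saturated chain carbon bound to a carbonyl carbon reads a 1.4-fold higher number from compound 2 to compound 3 (0.13 log units; within the scatter), so this assay does not separate the longer chain from the shorter one. The wider exchange on the amine nitrogen, (2-(diethylamino)ethyl)carbonyl in place of 2-((pyrrolidin-1-yl)carbonyl)ethyl, reads a 1.7-fold higher number from compound 1 to compound 3 (0.22 log units; within the scatter). No measurement shown explains these numbers.

Going by these compounds, whether a longer chain such as 3-(diethylamino)propyl, or a carboxylic acid at the chain end, would step beyond the scatter stays open. On these data alone, the effect of changes to the shared core also stays open.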